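Aryl variation at the pyrazole position of the series

A few compounds are considered here, and "the series" means these few. Any claim that something is new, unique, unknown or untested is made for them only; others in the source may bear on it.

Three compounds share one core and differ only in the aromatic group that sits on the five-membered ring. Compound 1 `Cc1nn(-c2nc(-c3ccc(Cl)c(Cl)c3)c(SC(C)C)s2)c(C(=O)O)c1-c1cncnc1` carries pyrimidin-5-yl; in a functional assay on BJAB cells (Homo sapiens) for antiproliferative activity, with a stated time of 4 days (on this read-out lower numbers stand for an effect already at smaller amounts and higher numbers for an effect only at larger amounts of compound), compound 1 gives 22000 nM. Compound 2 `COc1ccccc1-c1c(C)nn(-c2nc(-c3ccc(Cl)c(Cl)c3)c(SC(C)C)s2)c1C(=O)O` carries 2-methoxyphenyl and gives 14700 nM. Compound 3 `Cc1nn(-c2nc(-c3ccc(Cl)c(Cl)c3)c(SC(C)C)s2)c(C(=O)O)c1-c1cc(C(F)(F)F)cc(C(F)(F)F)c1` carries the bis(trifluoromethyl)phenyl group and gives 1800 nM. For the measured compounds named here, the only single-point step measured so far is a 1.5-fold lower number from compound 1 to compound 2 (0.18 log units; within the scatter), so compound 1 and compound 2 cannot be ordered against each other. Compound 2 stands second highest of the three numbers; compound 3 lies well beyond the scatter on the lower side.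

Compound 4 `Cc1nn(-c2nc(-c3ccc(Cl)c(Cl)c3)c(SC(C)C)s2)c(C(=O)O)c1-c1cccnc1` differs from compound 2 by pyridin-3-yl in place of 2-methoxyphenyl on an aromatic carbon. The step from compound 1 to compound 2 is the one that bears on this change, since it also swaps a six-membered aromatic group at the same place, and it stayed within the scatter. No step beyond the scatter is therefore expected here: the estimated step is a 1.2-fold higher number from compound 2 to compound 4 (0.09 log units; within the scatter). Compound 4 is expected to give about 18000 nM, with a range from 8000 nM to 40000 nM.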

Compound 4, half-maximal effective concentration: 12000 nM
Compound 4: the middle estimate sits 1.5-fold (0.18 log units) above what was measured; low and high end bracket the measured number.
By their numbers in this assay, from the lowest: compound 3; then compounds 4, 2 and 1 (each within the scatter of the next).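

In this assay, the two further exchanges at this aromatic carbon both stay within the scatter: the step is a 1.2-fold lower number from compound 2 to compound 4 (0.09 log units; within the scatter), and the step is a 1.8-fold lower number from compound 1 to compound 4 (0.26 log units; within the scatter). Pyridin-3-yl, 2-methoxyphenyl and pyrimidin-5-yl therefore cannot be ordered against one another, even though they differ in ring hetero atoms and heavy-atom count. Among the groups tried here, only the bis(trifluoromethyl)phenyl group of compound 3, at 1800 nM, gives a printed value well apart from these three. No measurement at hand bears on the reason for these results.

The compounds shown leave open how a phenyl ring with a single trifluoromethyl group would read at this position. The same holds for a phenyl ring bearing an amine or a carboxylic acid.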